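The source may report more compounds than this note shows. Statements on the series, on what has been measured and on what is new or still open speak of the compounds shown alone.

Measured compounds in a physicochemical assay for lipophilicity, measured as octanol-water partition; on this read-out higher numbers stand for higher lipophilicity and lower numbers for lower lipophilicity:
- compound 1 `COc1cc(NC(C)CCCN2C(=O)[C@@H](C)N(C(=O)CN)C2(C)C)c2ncccc2c1` gives 2.54
- compound 2 `COc1cc(NC(C)CCCN2C(=O)CN(C(=O)CN)C2(C)C)c2ncccc2c1` gives 2.19
- compound 3 `COc1cc(NC(C)CCCN2C(=O)[C@@H](C)NC2(C)C)c2ncccc2c1` gives 3.25

Compound 2 stands lowest of the three numbers. Its nearest neighbour is compound 1, and the step of a number 0.35 log units lower from compound 1 to compound 2 (beyond the scatter) is beyond the scatter; compound 3 lies furthest from it. The other measured step, a number 0.71 log units higher from compound 1 to compound 3 (beyond the scatter), is also beyond the scatter.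

Compound 4 `CC[C@H](C)[C@@H](N)C(=O)N1CC(=O)N(CCCC(C)Nc2cc(OC)cc3cccnc23)C1(C)C` is not yet measured in this assay. It differs from compound 2 in one place: sec-butyl in place of hydrogen on a saturated chain carbon bound to an amine nitrogen and a carbonyl carbon.

Within the data shown here, of the two measured steps, the one from compound 1 to compound 2 bears most directly, since it also concerns a single saturated carbon substituent: one methyl is worth a number 0.35 log units lower from compound 1 to compound 2 (beyond the scatter). The entering sec-butyl brings four carbons at a saturated chain carbon bound to an amine nitrogen and a carbonyl carbon, so a step in the other direction, and larger, is expected. The step from compound 1 to compound 3 concerns a different kind of change and gives only a rough sense of scale. For compound 2 to compound 4 a step of about a number 1.11 log units higher from compound 2 to compound 4 (beyond the scatter) in this assay is therefore expected, upward and well beyond the scatter. Compound 4 is estimated at 3.3, in the range 2.7 to 3.9.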

Compound 4, partition coefficient: 3.4
Compound 4: the middle estimate sits 0.10 log units below what was measured; measured number inside the range.
By their numbers in this assay, from the lowest: compound 2; then compound 1; then compounds 3 and 4 (each within the scatter of the next).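

Among these compounds, the change from aminomethyl to 1-amino-2-methylbutyl gives a number 1.21 log units higher from compound 2 to compound 4 (beyond the scatter) in this assay, and this is the first reading at the saturated chain carbon bound to an amine nitrogen and a carbonyl carbon. The earlier steps shown here either changed a saturated ring carbon or removed the whole (aminomethyl)carbonyl group, so they did not show how the read-out responds to a change within that group. Here, the step is larger than both a number 0.35 log units lower from compound 1 to compound 2 (beyond the scatter) and a number 0.71 log units higher from compound 1 to compound 3 (beyond the scatter) in the same assay, so a single substitution at this carbon can move the number further than removing the whole group did, although no available evidence explains the size of the step.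

With sec-butyl as the only group shown at this carbon, the compounds leave open how the number would follow a methyl, an isopropyl, a phenyl or a carboxylic acid there, or the opposite configuration at the sec-butyl stereocentre. They also leave open whether sec-butyl at this carbon would give a step of similar size on the core of compound 1, which carries a methyl on the saturated ring carbon.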